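The source may report more compounds than this note shows. Statements on the series, on what has been measured and on what is new or still open speak of the compounds shown alone.

Working notes on the series. Three compounds sharing one core have numbers in an assay on CHO cells for displacement of a labelled ligand from 5-hydroxytryptamine receptor 1D (Homo sapiens); on this read-out higher numbers stand for weaker inhibition and lower numbers for stronger inhibition. Compound 1 `CN(CC1CCN(CCCc2c[nH]c3ccc(-n4cnnc4)cc23)CC1)C(=O)Nc1ccccc1` gives 5.9 nM. Compound 2 `CC(C)=CCCN(C)C1CCN(CCCc2c[nH]c3ccc(-n4cnnc4)cc23)CC1` gives 2.6 nM, the second highest of the three: compound 1 sits a clear step higher, beyond the scatter, and compound 3 a larger step lower, also beyond the scatter. Compound 3 `CC(=O)Nc1ccc([C@H](C)NCC2CCN(CCCc3c[nH]c4ccc(-n5cnnc5)cc34)CC2)cc1` gives 0.6 nM, the lowest number of the set, with an amino-linked aromatic group on the saturated ring.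

Compound 4 `c1cncc(CNC2CCN(CCCc3c[nH]c4ccc(-n5cnnc5)cc34)CC2)c1` has not yet been measured in this assay. The change from compound 2 is ((pyridin-3-yl)methyl)amino in place of methyl(4-methylpent-3-en-1-yl)amino on a saturated ring carbon. Within the data shown here, no measured pair shows this change, so the size of the step is not known from the data. The closest guide is compound 3, which also carries an amino-linked aromatic group and gives 0.6 nM, lower than compound 2.

On that basis compound 4 is expected to bind somewhat more strongly than compound 2. The step expected from compound 2 is a 1.7-fold lower number from compound 2 to compound 4 (0.24 log units; within the scatter), a modest move toward lower numbers, not certain to clear the scatter. Compound 4 is estimated at 1.5 nM, with a range from 0.5 nM to 5 nM.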

Compound 4, half-maximal inhibitory concentration: 35 nM
Estimate against measurement, compound 4: 23-fold (1.37 log units) below; the whole stated range lies below it.
By their numbers in this assay, from the lowest: compound 3; then compound 2; then compound 1; then compound 4.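

In this assay, the saturated ring carbon proves sensitive to the group it carries: ((pyridin-3-yl)methyl)amino in place of methyl(4-methylpent-3-en-1-yl)amino gives a 13-fold higher number from compound 2 to compound 4 (1.13 log units; beyond the scatter). Both groups have 8 heavy atoms, so the large step arises with no change in that count, while the change brings in a six-membered aromatic ring and 1 hydrogen-bond donor and removes the double bond and the methyl on the amine nitrogen. Nothing available ties the step to any one of these differences.

The compounds shown leave open which of these differences carries the step. Open in particular is whether a benzylamino group, with a phenyl ring in place of pyridin-3-yl, or a methyl on the amine nitrogen of compound 4 would bring the number back toward that of compound 2.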